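Triazole-linked dienones: moving the benzyl fluorine

A few compounds are considered here, and "the series" means these few. Any claim that something is new, unique, unknown or untested is made for them only; others in the source may bear on it.

Measured so far:
compound 1 `O=C1/C(=C/c2ccccc2F)CN(Cc2cn(Cc3ccc(F)cc3)nn2)C/C1=C\c1ccccc1F`, 6000 nM in a functional assay on MCF7 cells (Homo sapiens) for cytotoxicity, read by MTT assay, with a stated time of 24 h; on this read-out higher numbers stand for weaker inhibition and lower numbers for stronger inhibition
compound 2 `COc1ccc(/C=C2\CN(C(=S)SCc3cn(Cc4ccc(F)cc4)nn3)C/C(=C\c3ccc(OC)cc3)C2=O)cc1`, > 100000 nM in this assay

Compound 2 gives only a limit, not a number, in this assay: the limit of > 100000 nM in this assay, at which 1 of the 2 values shown sits. Compound 1, of a different core, gives a numerical value in this assay, 6000 nM.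

Compound 3 `COc1ccc(/C=C2\CN(C(=S)SCc3cn(Cc4ccccc4F)nn3)C/C(=C\c3ccc(OC)cc3)C2=O)cc1` is not yet measured. It differs from compound 2 in one place: 2-fluorophenyl in place of 4-fluorophenyl on a saturated chain carbon bound to an aromatic nitrogen. For the measured compounds named here, no measured pair shows this change on the core of compound 2.

The step of a number no higher from compound 2 to compound 3 (the limit leaves the size open) is expected to stay within the scatter, with no set direction. Compound 3 is therefore estimated at 100000 nM, within 30000 nM to 300000 nM, and most likely again reported only as a limit in this assay.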

Compound 3, half-maximal inhibitory concentration: 79400 nM
The estimate for compound 3 lay 1.3-fold (0.10 log units) above the measured number, within the range that was stated.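

In this assay, for the compounds shown here, compound 3 gives a number where compound 2 gives only a limit, so 2-fluorobenzyl provides the first numerical reading at this position on the core of compound 2. The change from 4-fluorobenzyl reads as an at least 1.2-fold lower number from compound 2 to compound 3 (0.10 log units; that floor lies within the scatter) and leaves the full size of the step open. Compound 2 remains a limit rather than a number: the limit of > 100000 nM in this assay, at which 1 of the 3 values shown sits.

The compounds shown leave open how the same change reads on the core of compound 1. Also open, going by these compounds, is how an unsubstituted benzyl group or a longer chain bearing an amine would read at this position.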